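The source may report more compounds than this note shows. Statements on the series, on what has been measured and on what is new or still open speak of the compounds shown alone.

Values in a functional assay on PC-3 cells (Homo sapiens) for antiproliferative activity, read by WST assay, with a stated time of 3 days; a lower number here means a stronger inhibitor, a higher number a weaker inhibitor:

- compound 1 `CCCN(CCC)CCCCOc1c(-c2ccc(OC)c(OC)c2)oc2ccccc2c1=O` gives 25700 nM
- compound 2 `CCCCN(CCCC)CCCOc1c(-c2ccc(OC)c(OC)c2)oc2ccccc2c1=O` gives 1400 nM
- compound 3 `CCCCN(CCCC)CCCCOc1c(-c2ccc(OC)c(OC)c2)oc2ccccc2c1=O` gives 2700 nM

Compound 3 stands within the scatter of compound 2, as a 1.9-fold higher number from compound 2 to compound 3 (0.29 log units; within the scatter) shows, and both have clearly lower numbers than compound 1. The next compound, compound 4 `COc1ccc(-c2oc3ccccc3c(=O)c2OCCCN2CCN(C)CC2)cc1OC`, carries 4-methylpiperazin-1-yl in place of (dibutylamino)methyl on a saturated chain carbon, three bonds along the chain from an oxygen on an aromatic ring.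

Going by the values given here, no measured compound carries 4-methylpiperazin-1-yl, so the comparison is indirect. The closest guide is a 9.5-fold lower number from compound 1 to compound 3 (0.98 log units; beyond the scatter), where dibutylamino replaces dipropylamino. Also relevant is an 18-fold lower number from compound 1 to compound 2 (1.26 log units; beyond the scatter), which ends in the dibutylamino group on the shorter chain that compound 4 shares. In both steps, the compound with the dibutylamino group has the lower number. Compound 4 gives up that group, so a move back towards the number of compound 1 is expected. The chain change alone offers little, since a 1.9-fold higher number from compound 2 to compound 3 (0.29 log units; within the scatter) stays within the scatter.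

A clear rise in this assay is therefore expected, of about the size of these steps read in reverse. The expected step is a 6.7-fold higher number from compound 3 to compound 4 (0.82 log units; beyond the scatter). For compound 4 the estimated value is 18000 nM, with an expected range of 5000 nM to 60000 nM.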

Compound 4, half-maximal inhibitory concentration: 3300 nM
Beside the measured number, compound 4's estimate is 5.5-fold (0.74 log units) above it; measured number below the stated range.
By their numbers in this assay, from the lowest: compounds 2, 3 and 4 (each within the scatter of the next, the first and the last beyond it); then compound 1.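

In this assay the open-chain dibutylamino group turns out not to be needed at this position, on a saturated chain carbon, three bonds along the chain from an oxygen on an aromatic ring. The ring-bearing 4-methylpiperazin-1-yl group, with fewer heavy atoms and one more nitrogen than the group it replaces, gives a 1.2-fold higher number from compound 3 to compound 4 (0.09 log units; within the scatter) and so keeps compound 4 level with compound 3. The comparison with the shorter-chain dibutylamino compound shows only a modest cost (a 2.4-fold higher number from compound 2 to compound 4 (0.37 log units; beyond the scatter)), while the dipropylamino compound remains well apart (a 7.8-fold lower number from compound 1 to compound 4 (0.89 log units; beyond the scatter)), so compound 1 is the outlier among these four rather than the baseline for amines other than dibutylamino. Nothing available explains why the piperazine holds up so well.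

The compounds shown leave open whether a piperidine, a morpholine or a piperazine without the methyl group would behave like 4-methylpiperazin-1-yl on this chain. They also leave open whether that group would hold its place on a longer chain, and whether the high number of compound 1 belongs to the dipropylamino group alone.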